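The source may report more compounds than this note shows. Statements on the series, on what has been measured and on what is new or still open speak of the compounds shown alone.

Three compounds on the shared core have been run in a functional assay on a cell-free system (plasma) with sterol O-acyltransferase, Soat (Rattus norvegicus) as the target; a higher number here means that more compound is needed for the effect, a lower number that less compound is needed. Compound 1 `Cc1cc(C)c(NC(=O)N(Cc2ccc(-c3n[nH]c(C)n3)cc2)C2CCCCCC2)c(C)c1` gives only a limit, > 1 mg/kg. Compound 2 `Cc1cc(C)c(NC(=O)N(Cc2ccccc2)Cc2cccc(-c3cc[nH]n3)c2)c(C)c1` likewise gives only a limit, > 1 mg/kg. Among the compounds with values here, compound 3 `O=C(Nc1c(F)cc(F)cc1F)N(Cc1ccccc1)Cc1cccc(-c2cc[nH]n2)c1` is the one member with a number: in this assay compound 3 gives 0.096 mg/kg. On the numbers shown compound 3 therefore stands alone as the sole value, the rest sitting at the limit of > 1 mg/kg in this assay, at which 2 of the 3 values shown sit.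

Within the data shown here, the single measured step is an at least 10-fold lower number from compound 2 to compound 3 (1.01 log units; beyond the scatter), a change on the amide-type nitrogen. Compound 4 `O=C(Nc1c(F)cc(F)cc1F)N(Cc1ccc(F)cc1)Cc1cccc(-c2cc[nH]n2)c1` differs from compound 3 elsewhere: fluoro in place of hydrogen on an aromatic carbon, which read one bond further out is phenyl to 4-fluorophenyl, benzyl to 4-fluorobenzyl. Among the measured compounds shown here, no measured step touches this benzyl ring; the step from compound 2 to compound 3 concerns the aryl on the amide nitrogen and gives no guide to the size of a change on the benzyl. With nothing in the series to point either way, the step of a 1.0-fold higher number from compound 3 to compound 4 (0.02 log units; within the scatter) is estimated to lie within the scatter. Compound 4 is thus expected at about 0.1 mg/kg in this assay, with a range of 0.03 mg/kg to 0.35 mg/kg.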

Compound 4, dose for half-maximal effect: < 0.32 mg/kg
Compound 4 was reported as a limit; the forecaster's own chance of this, stated with the estimate: 10%; the middle value does not contradict the limit.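

In this assay compound 4 gives < 0.32 mg/kg, which is a limit and not a number, so the step from compound 3 to compound 4 cannot be read. The compounds shown leave open whether 4-fluorobenzyl in place of benzyl on the shared core changes the read-out in this assay at all, and in which direction.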